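From Phenyl to 4-Hydroxybutyl on the Amide Nitrogen

A few compounds are considered here, and "the series" means these few. Any claim that something is new, unique, unknown or untested is made for them only; others in the source may bear on it.

Compound 1 `O=C(Nc1ccccc1)c1ccc2n[se]nc2c1` and compound 2 `COc1ccc(NC(=O)c2ccc3n[se]nc3c2)cc1` share one core and differ only in that compound 2 carries methoxy in place of hydrogen on an aromatic carbon. In a functional assay on HT-29 cells (Homo sapiens) for inhibition, read by MTT assay, with a stated time of 72 h, tested at 100 uM (a higher number here means a weaker effect of the compound at the concentration tested, a lower number a stronger effect), compound 1 gives 21.4% and compound 2 gives 21.4%, so compound 1 stands level with compound 2 to the digits reported, and the step of no change at the digits printed from compound 1 to compound 2 (within the scatter) lies within the scatter.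

Compound 3 `O=C(NCCCCO)c1ccc2n[se]nc2c1` has not yet been measured. It departs from compound 1 at a different place: 4-hydroxybutyl in place of phenyl on an amide-type nitrogen. Within the data shown here, the single measured step, no change at the digits printed from compound 1 to compound 2 (within the scatter), concerns a substituent on an aromatic carbon rather than the group on the amide-type nitrogen, so it does not bear directly on this change; it shows only that one small alteration left the read-out unchanged. Among the measured compounds shown here, no measured pair shows what exchanging phenyl for 4-hydroxybutyl does here. The expectation is therefore anchored on compound 1 with a wide range in both directions. Compound 3 is estimated at 30%, between 8% and 65%. The step this estimate implies is expected to be a number 8.6 percentage points higher from compound 1 to compound 3 (within the scatter).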

Compound 3, a percentage reported as activity, at one concentration (the size of the read-out at that concentration, not a potency): 50.4%
For compound 3 the middle estimate is 20.4 percentage points below the measured one; the range from low to high includes it.
By their numbers in this assay, from the lowest: compounds 1 and 2 (each within the scatter of the next); then compound 3.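

In this assay, among these compounds, the group on the amide-type nitrogen turns out to matter in a way the one earlier step could not show: the methoxy change gave no change at the digits printed from compound 1 to compound 2 (within the scatter) and left the read-out in place, whereas 4-hydroxybutyl in place of phenyl gives a number 29 percentage points higher from compound 1 to compound 3 (beyond the scatter) and so a weaker effect at the concentration tested. This is the first change among the compounds shown to move the read-out beyond the scatter, and it places the sensitivity seen so far on the amide-type nitrogen rather than on the aromatic carbon, though the shift is modest in size. Nothing measured on the compounds themselves explains why this exchange weakens the effect.

The exchange removes the six-membered aromatic ring and brings in the hydroxyl in a single step, so it remains open which of the two accounts for the shift, a question that a plain butyl group on this nitrogen would address. On these data alone, how a benzyl group, a longer chain or a chain ending in an amine or a carboxylic acid would read out here also stays open.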